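The compounds below may be only part of what the source reports. "The series", "measured", "known", "first", "only" and "open" are said of these compounds alone.

Values in an ADME assay on L6 cells (Rattus norvegicus) for cytotoxicity; on this read-out lower numbers stand for stronger inhibition and higher numbers for weaker inhibition:

- Compound 1 `N=C(N)c1cccc(-c2cc3ccc(C(=N)N)cc3o2)c1`: 131000 nM
- Compound 2 `COc1ccc(C(=N)N)cc1-c1cc2ccc(C(=N)N)cc2o1`: 128000 nM

Going by the values given here, only two compounds have been measured, and at 128000 nM compound 2 stands level with compound 1 within the usual scatter. The next compound, compound 3 `N=C(N)c1ccc(O)c(-c2cc3ccc(C(=N)N)cc3o2)c1`, differs from compound 2 at a single point: hydrogen in place of methyl on an oxygen on an aromatic ring. In words, this is hydrogen in place of methyl on an oxygen on an aromatic ring, or methoxy to hydroxy.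

Among the compounds with values here, the one measured step that bears on this change is a 1.0-fold lower number from compound 1 to compound 2 (0.01 log units; within the scatter), for methoxy in place of hydrogen on an aromatic carbon. Adding the methoxy made no difference beyond the scatter, so no large step is expected here, although no hydroxy compound has been measured yet. The expected change is a 1.3-fold lower number from compound 2 to compound 3 (0.11 log units; within the scatter). For compound 3 the estimated value is 100000 nM, with an expected range of 35000 nM to 190000 nM.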

Compound 3, half-maximal inhibitory concentration: 164000 nM
For compound 3 the middle estimate is 1.6-fold (0.21 log units) below the measured one; measured number inside the range.
By their numbers in this assay, from the lowest: compounds 2, 1 and 3 (each within the scatter of the next).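

In this assay, hydroxy in place of methoxy gives a 1.3-fold higher number from compound 2 to compound 3 (0.11 log units; within the scatter), and hydroxy in place of hydrogen on the aromatic carbon gives a 1.3-fold higher number from compound 1 to compound 3 (0.10 log units; within the scatter); both steps lie within the scatter. The earlier pair showed only that methoxy and hydrogen could not be told apart at this position, whereas compound 3 adds a third group, and hydrogen, methoxy and hydroxy now all give numbers within the scatter of one another. Nothing measured here offers a reason for this flat result.

From the compounds shown here alone, whether an amine, a carboxylic acid or a longer chain such as ethoxy at this same position would also stay within the scatter remains open. Going by these compounds, it is equally open whether a halogen such as fluorine or chlorine would behave like these three groups.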